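The source may report more compounds than this note shows. Statements on the series, on what has been measured and on what is new or still open speak of the compounds shown alone.

Measured compounds:
compound 1, `CCCCc1nc2c(C)ccnc2n1Cc1ccc(-c2ccccc2C(=O)O)cc1`, gives 7.94 nM in a functional assay (aorta) with Oryctolagus cuniculus as the target; a lower number here means tighter binding, a higher number weaker binding
compound 2, `Cc1ccnc2c1nc(C1CCC1)n2Cc1ccc(-c2ccccc2C(=O)O)cc1`, gives 5.01 nM in this assay

Compound 2 has the lowest of these two numbers, yet compound 1 sits within the scatter of it: a 1.6-fold lower number from compound 1 to compound 2 (0.20 log units; within the scatter). Compound 3, `Cc1ccnc2c1nc(CCCO)n2Cc1ccc(-c2ccccc2C(=O)O)cc1`, is not yet measured. It differs from compound 2 in one place: 3-hydroxypropyl in place of cyclobutyl on an aromatic carbon. Going by the values given here, the only measured step changes the same aromatic carbon, from butyl to cyclobutyl, and stayed within the scatter; no measured step involves a 3-hydroxypropyl group. For compound 3 a modest shift is therefore expected, a 2.0-fold higher number from compound 2 to compound 3 (0.30 log units; within the scatter), with the direction uncertain. Compound 3 is estimated at 10 nM, between 3 nM and 40 nM.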

Compound 3, dissociation constant: 501 nM
Beside the measured number, compound 3's estimate is 50-fold (1.70 log units) below it; measured number above the stated range.
By their numbers in this assay, from the lowest: compounds 2 and 1 (each within the scatter of the next); then compound 3.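

On this aromatic carbon, the change of group can matter a great deal: in this assay, 3-hydroxypropyl in place of cyclobutyl gives a 100-fold higher number from compound 2 to compound 3 (2.00 log units; beyond the scatter), whereas the earlier change stayed within the scatter. Keeping the chain and putting hydroxy in place of methyl gives a 63-fold higher number from compound 1 to compound 3 (1.80 log units; beyond the scatter), so this single swap on the chain is enough for a large step. Nothing measured here explains the step. Still open, on these data alone, is how a methoxy group, an amine or a carboxylic acid in place of the hydroxy would read, and whether a shorter or longer hydroxy-bearing chain would read the same.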